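Methyl in Place of Chloro on the Fused Ring

This account rests on a few compounds, and the source may have more. Where it says the series, first, only, none or still open, it means among the compounds named here.

Measured so far:
compound 1, `O=C(Nc1cccc2[nH]ncc12)NC1CCc2ncccc21`: 5820 nM
compound 2, `O=C(Nc1cccc2[nH]ncc12)NC1CCc2cc(Cl)ccc21`: 10 nM

Both compounds were tested in an assay on isolated protein for inhibition of transient receptor potential cation channel subfamily V member 1 (Homo sapiens), read by calcium flux; a lower number here means a stronger inhibitor, a higher number a weaker inhibitor. Of the two numbers, compound 2 has the lower one, and compound 1 stands far higher, well beyond the usual scatter. The two compounds differ in more than one place, so no single change can be read from that gap; it only shows that the chloro-bearing arrangement of compound 2 is the strong one here.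

Going by the values given here, compound 3, `Cc1ccc2c(c1)CCC2NC(=O)Nc1cccc2[nH]ncc12`, keeps the whole core of compound 2 and alters only one group: methyl in place of chloro on an aromatic carbon. Among the compounds with values here, nothing among the measured compounds shows what a chloro-to-methyl swap at this position does on its own, so the size of the step rests on the similarity of the two groups, each a single heavy atom and neither a donor nor an acceptor.

The step of a 3.0-fold higher number from compound 2 to compound 3 (0.48 log units; beyond the scatter) is expected to be modest, most likely a small loss in this assay that may not exceed the scatter. Compound 3 is therefore expected to give about 30 nM, within a range from 8 nM to 120 nM.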

Compound 3, half-maximal inhibitory concentration: 11 nM
Compound 3: the middle estimate sits 2.7-fold (0.44 log units) above what was measured, within the range that was stated.
By their numbers in this assay, from the lowest: compounds 2 and 3 (each within the scatter of the next); then compound 1.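

In this assay, putting methyl in place of chloro on this aromatic carbon gives a 1.1-fold higher number from compound 2 to compound 3 (0.04 log units; within the scatter), so in this pair the two groups cannot be told apart by their numbers. The earlier compounds shown here offered no single change to read, whereas this pair differs in one group only and shows that the chlorine itself is not needed here: with the rest of the molecule unchanged, a methyl on the same carbon keeps the number at the level of the chloro compound. Nothing measured here explains why the two groups give such similar results in this assay.

From the compounds shown here alone, whether this position accepts only these two groups stays open, since a methoxy group, an amine, a carboxylic acid or a longer chain such as propyl might keep the number where it is or raise it sharply. A single pair also cannot say whether the same swap would give so small a step on another carbon of this six-membered ring or on a different core.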